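Chloro to Trifluoromethyl on a Biguanide Aryl Ring

The source may hold more compounds than are shown below. What is called first, only, known or untested is meant among the compounds shown, and "the series" means these compounds.

Compound 1 `CCCCCCCCNC(=N)NC(=N)Nc1ccc(OC)cc1`: 4.41
Compound 2 `CCCCCCNC(=N)NC(=N)Nc1ccc(C(F)(F)F)cc1`: 4.31
Compound 3 `CCCCCCCCNC(=N)NC(=N)Nc1ccc(Cl)cc1`: 5.13

In a physicochemical assay for lipophilicity, in phosphate buffer, measured as octanol-water partition, at pH 11.5 (on this read-out higher numbers stand for higher lipophilicity and lower numbers for lower lipophilicity), compound 3 has the highest number of the three; compound 1 sits a number 0.72 log units higher from compound 1 to compound 3 (beyond the scatter). Compound 4 `CCCCCCCCNC(=N)NC(=N)Nc1ccc(C(F)(F)F)cc1` differs from compound 3 by trifluoromethyl in place of chloro on an aromatic carbon. Within the data shown here, no measured step covers this exact change. Compound 2 carries the same trifluoromethyl group but also a shorter chain, so its value only sets a loose lower reference. Among the measured compounds shown here, the one measured step, from methoxy to chloro, was modest and upward. On this basis compound 4 is expected to land near compound 3 or a little above it, with a number 0.17 log units higher from compound 3 to compound 4 (within the scatter) expected. Compound 4 is estimated at 5.3, with a range of 4.8 to 5.8.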

Compound 4, partition coefficient: 5.31
Compound 4: middle estimate off by 0.01 log units, on the low side; the measured number falls inside the stated range.
By their numbers in this assay, from the lowest: compounds 2 and 1 (each within the scatter of the next); then compounds 3 and 4 (each within the scatter of the next).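

In this assay, the step at this aromatic carbon, para to a large group, is a number 0.18 log units higher from compound 3 to compound 4 (within the scatter), so chloro and trifluoromethyl are not separated on this read-out. Trifluoromethyl in place of methoxy gives a number 0.90 log units higher from compound 1 to compound 4 (beyond the scatter), a step beyond the scatter at the same position. With trifluoromethyl held fixed, ethyl in place of hydrogen on the chain gives a number 1.00 log units higher from compound 2 to compound 4 (beyond the scatter), isolating a change of chain length.

As far as these compounds go, whether a nitrile or an amine at this position would stay level with chloro and trifluoromethyl remains open, as does the effect of a longer chain on this number. Nothing shown here explains these steps.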